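The compounds below may be only part of what the source reports. "The series", "measured", "known", "first", "only" and "open" are said of these compounds alone.

Compound 1 `Cc1ccc(S(=O)(=O)Nc2ccc(NS(=O)(=O)c3ccc(F)cc3)cc2)cc1`: in an assay for inhibition of liver carboxylesterase 1 (Homo sapiens), read by spectrophotometry (a higher number here means a weaker inhibitor, a lower number a stronger inhibitor), compound 1 gives > 100000 nM, a limit of the assay rather than a number.
Compound 2 `Cc1ccc(S(=O)(=O)Nc2ccc(NS(=O)(=O)c3ccc(F)c(F)c3)cc2)cc1`: compound 2 gives > 100000 nM, again a limit.
Compound 3 `O=S(=O)(Nc1ccc(NS(=O)(=O)c2ccc(Cl)cc2)cc1)c1ccc(F)cc1`: compound 3 gives > 100000 nM, also a limit.

Compound 3 therefore stands at the edge of what this assay reports, as described by the limit of > 100000 nM in this assay, at which 3 of the 3 values shown sit. The two measured steps, a step that the two limits leave unreadable from compound 1 to compound 2 and a step that the two limits leave unreadable from compound 1 to compound 3, both run between limits and so carry no readable size. Compound 4 `Cc1ccc(S(=O)(=O)Nc2ccc(NS(=O)(=O)c3ccc(Cl)cc3)cc2)cc1` differs from compound 3 by methyl in place of fluoro on an aromatic carbon. For the measured compounds named here, no measured step bears on this change with a readable size; every value so far is a limit. The estimated step that the limit leaves unreadable from compound 3 to compound 4 is accordingly expected to be none beyond the scatter. Compound 4 is expected to give about 150000 nM, within 60000 nM to 400000 nM, most probably reported once more as a limit.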

Compound 4, inhibition constant: > 100000 nM
Compound 4 was reported as a limit (the forecaster's own chance of this, stated with the estimate: 85%); the middle value lies beyond the limit too.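

Compound 4 adds no readable step to compound 1, compound 2 or compound 3, since all four sit at the same limit: the limit of > 100000 nM in this assay, at which 4 of the 4 values shown sit. The compounds shown leave open how far any change to the shared core moves the read-out in this assay within the range of the assay.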